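Working notes: bromo in place of hydrogen, compound 3

The source may hold more compounds than are shown below. What is called first, only, known or untested is meant among the compounds shown, and "the series" means these compounds.

- Compound 1 `CC1(C)[C@H]2CC[C@]1(C)N(Cc1cn(-c3cccc(Cl)c3)nn1)C(=O)C2`: 8510 nM
- Compound 2 `CC1(C)[C@H]2CC[C@]1(C)N(Cc1cn(-c3ccccc3)nn1)C(=O)C2`: 6230 nM

Both values come from an ADME assay on L02 cells (Homo sapiens) for cytotoxicity, read by MTT assay, with a stated time of 24 h; a higher number here means that more compound is tolerated, a lower number that less compound is tolerated. Among the compounds with values here, compound 2 lies within the scatter of compound 1, the only other measured compound, so the two cannot be ranked. The next compound is compound 3 `CC1(C)[C@H]2CC[C@]1(C)N(Cc1cn(-c3cccc(Br)c3)nn1)C(=O)C2`, whose difference from compound 2 is bromo in place of hydrogen on an aromatic carbon. In words, this is bromo in place of hydrogen on an aromatic carbon. Within the data shown here, one measured step bears on this change, the loss of chloro from the same ring carbon: a 1.4-fold lower number from compound 1 to compound 2 (0.14 log units; within the scatter). This single step gives no sign of a shift when a halogen replaces hydrogen there, so no step beyond the scatter is expected in this assay. The expected step is a 1.3-fold higher number from compound 2 to compound 3 (0.11 log units; within the scatter). Compound 3 is estimated at 8000 nM, with an expected range of 4500 nM to 14000 nM.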

Compound 3, half-maximal cytotoxic concentration: 10500 nM
Compound 3: the middle estimate sits 1.3-fold (0.12 log units) below what was measured, within the range that was stated.
By their numbers in this assay, from the lowest: compounds 2, 1 and 3 (each within the scatter of the next).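

With bromo in place of hydrogen on this aromatic carbon, the step in this assay is a 1.7-fold higher number from compound 2 to compound 3 (0.23 log units; within the scatter), and with bromo in place of chloro it is a 1.2-fold higher number from compound 1 to compound 3 (0.09 log units; within the scatter). Chloro and bromo on this carbon therefore cannot be told apart from each other or from hydrogen, and a second halogen now gives the same reading as the first: compounds 1, 2 and 3 cannot be ranked in this assay. No measurement on hand offers an explanation for these numbers.

As far as these compounds go, whether an amine, a carboxylic acid or a longer alkyl chain on this same carbon would give a step beyond the scatter remains open. Also open, from the compounds shown here alone, is whether fluoro or iodo here would read like chloro and bromo.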